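The compounds below may be only part of what the source reports. "The series", "measured", "known", "first", "only" and "open" are said of these compounds alone.

Compound 1 `COc1ccc(N)c(C(=O)CCNC(=O)c2ccccc2)c1` and compound 2 `Nc1ccc(Cl)cc1C(=O)CCNC(=O)c1ccccc1` share one core, while compound 3 `CNC(=S)NCCC(O)c1cc(OC)ccc1N` and compound 4 `CNC(=S)NCCC(O)c1cc(Cl)ccc1N` share another; the difference between the two cores is not broken down here. In an assay for inhibition of Nitric oxide synthase, inducible (Homo sapiens), read by scintillation counting, with a stated time of 30 min, tested at 1 mM (a lower number here means less inhibition, a higher number more inhibition at the concentration tested (going by the name of the read-out)), compound 1 gives 10.9%, compound 2 gives 26.6% and compound 3 gives 76.6%. The change from compound 1 to compound 2 is chloro in place of methoxy on an aromatic carbon and it made the step of a number 15.7 percentage points higher from compound 1 to compound 2 (beyond the scatter). The change from compound 3 to compound 4 is chloro in place of methoxy on an aromatic carbon, the same kind of change on a different core, its place described as meta to a group of 9 heavy atoms rather than meta to a large group. Compound 4 is expected to show the step of a number 8.4 percentage points higher from compound 3 to compound 4 (within the scatter) in this assay. That expectation rests on the step of a number 15.7 percentage points higher from compound 1 to compound 2 (beyond the scatter), tempered because compound 3 already stands at 76.6%. The estimate for compound 4 is 85%, between 65% and 97%.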

Compound 4, a percentage reported as inhibition, at one concentration (the size of the read-out at that concentration, not a potency): 22.1%
Compound 4: the middle estimate sits 62.9 percentage points above what was measured, and the stated range ends above it.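

In this assay, chloro in place of methoxy gave a number 54.5 percentage points lower from compound 3 to compound 4 (beyond the scatter), so the gain seen on the core of compound 1 did not carry over to the core of compound 3. The two steps go in opposite directions and clearly differ: the same change on two cores in this assay, a number 15.7 percentage points higher (beyond the scatter) from compound 1 to compound 2 and a number 54.5 percentage points lower (beyond the scatter) from compound 3 to compound 4, 70.2 percentage points apart, beyond the scatter of two such steps. Going by these compounds alone, this shows that the effect of this change depends on the core in these four compounds, but with only one pair per core, it does not show which feature of the cores is responsible or predict the outcome on any other core.

From the compounds shown here alone, it remains open how a fluoro or nitrile group at this place would compare with chloro and methoxy on each core. Also open, going by these compounds, is whether a third core would follow either pair.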